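Fluoro for hydrogen on the outer phenyl: series notes

The source may hold more compounds than are shown below. What is called first, only, known or untested is meant among the compounds shown, and "the series" means these compounds.

Measured in a functional assay on MCF7 cells (Homo sapiens) for cytotoxicity, read by MTT assay, with a stated time of 2 days, tested at 1 uM; on this read-out lower numbers stand for a stronger effect and higher numbers for a weaker effect at the one concentration tested:
compound 1 `CC(=O)c1cc(-c2ccccc2)cc2cc(-c3ccccc3)[nH]c12` — 98.6%
compound 2 `CC(=O)c1cc(-c2ccc(F)cc2)cc2cc(-c3ccccc3)[nH]c12` — 82.7%
compound 3 `CC(=O)c1cc(/C=C/c2ccccc2)cc2cc(-c3ccc(F)cc3)[nH]c12` — 86.9%

Compound 1 and compound 2 share a core and differ by fluoro in place of hydrogen on an aromatic carbon; in this assay the step is a number 15.9 percentage points lower from compound 1 to compound 2 (beyond the scatter). The difference between the core of compound 1 and the core of compound 3 is not broken down here. Compound 3 and compound 2 give numbers within the scatter of each other.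

Compound 4 `CC(=O)c1cc(/C=C/c2ccc(F)cc2)cc2cc(-c3ccc(F)cc3)[nH]c12` is not yet measured. It differs from compound 3 by fluoro in place of hydrogen on an aromatic carbon, the same change as from compound 1 to compound 2. On that basis, a step of similar size is expected in this assay, a number 13.9 percentage points lower from compound 3 to compound 4 (beyond the scatter), resting on a number 15.9 percentage points lower from compound 1 to compound 2 (beyond the scatter) and on compound 3 giving 86.9%. Compound 4 is therefore estimated at 73%, between 58% and 90%.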

Compound 4, a percentage reported as activity, at one concentration (the size of the read-out at that concentration, not a potency): 82%
The estimate for compound 4 lay 9 percentage points below the measured number, and the stated range covers the measured number.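

In this assay, the second core gives a step of its own for fluoro in place of hydrogen: a number 4.9 percentage points lower from compound 3 to compound 4 (within the scatter). Set beside the earlier step, the result does not separate the two cores: the same change on two cores in this assay, a number 15.9 percentage points lower (beyond the scatter) from compound 1 to compound 2 and a number 4.9 percentage points lower (within the scatter) from compound 3 to compound 4, 11 percentage points apart, within the scatter of two such steps. Among these compounds, this is compatible with the change carrying over from one core to the other, but it does not establish a step of constant size, since only two pairs are available and the step on the second core cannot be told from scatter.

The compounds shown leave open whether chloro, methoxy or an amine in place of the fluoro would move the number on either core. Each compound was read at one concentration, and the numbers speak only of a stronger or weaker effect at that concentration.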